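The compounds below may be only part of what the source reports. "The series", "measured", "known", "first", "only" and "open" are said of these compounds alone.

Measured in a functional assay on HepG2 cells (Homo sapiens) for antiproliferative activity, read by CCK-8 assay, with a stated time of 48 h; on this read-out lower numbers stand for stronger inhibition and higher numbers for weaker inhibition:
- compound 1 `COc1ccc(/C=C\c2cc(OC)c(OC)c(OC)c2)cc1OCc1ccc(CNC(C)(C)C(=O)O)cc1`: 6500 nM
- compound 2 `COc1ccc(/C=C\c2cc(OC)c(OC)c(OC)c2)cc1OCc1ccc(CN2CCCC[C@@H]2C(=O)O)cc1`: > 10000 nM (a limit of the assay, not a number)
- compound 3 `COc1ccc(/C=C\c2cc(OC)c(OC)c(OC)c2)cc1OCc1ccc(CN2CC[C@H](C(=O)O)C2)cc1`: 6400 nM

Compound 3 shares its place on the scale with compound 1, since the two values lie within the scatter of each other: a 1.0-fold lower number from compound 1 to compound 3 (0.01 log units; within the scatter). Compound 2 reaches only a limit, so it gives no exact number to compare.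

Compound 4 `COc1ccc(/C=C\c2cc(OC)c(OC)c(OC)c2)cc1OCc1ccc(CO)cc1` keeps the shared core of compound 3 and has hydroxy in place of 3-carboxypyrrolidin-1-yl on a saturated chain carbon bound to an aromatic carbon.

The measured steps only swap one carboxy-bearing amino group for another: an at least 1.5-fold higher number from compound 1 to compound 2 (0.18 log units; that floor lies within the scatter) and an at least 1.5-fold lower number from compound 2 to compound 3 (0.19 log units; that floor lies within the scatter). Both of these rest on (the limit of > 10000 nM in this assay, at which 1 of the 3 values shown sits), so they are floors rather than full sizes. None of the three steps is shown beyond the scatter, and none removes the carboxy-bearing group, so they guide this larger change only loosely. Compound 3 at 6400 nM already lies near the point where the assay stops giving numbers, so a move toward a lower number seems the more likely direction.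

In this assay the expected change is an 8.0-fold lower number from compound 3 to compound 4 (0.90 log units; beyond the scatter), though this expectation is uncertain. For compound 4 the estimate is 800 nM, with an expected range of 100 nM to 6000 nM.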

Compound 4, half-maximal inhibitory concentration: 2400 nM
The estimate for compound 4 lay 3.0-fold (0.48 log units) below the measured number; low and high end bracket the measured number.
By their numbers in this assay, from the lowest: compound 4; then compounds 3 and 1 (each within the scatter of the next). At a limit, above all of these: compound 2.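

In this assay, the earlier steps only traded one carboxy-bearing amino group for another, and none of them was shown beyond the scatter. Within the data shown here, putting hydroxy at this place, on a saturated chain carbon bound to an aromatic carbon, gives the first changes that are beyond it: a 2.7-fold lower number from compound 3 to compound 4 (0.43 log units; beyond the scatter) and a 2.7-fold lower number from compound 1 to compound 4 (0.43 log units; beyond the scatter). The same change gives an at least 4.1-fold lower number from compound 2 to compound 4 (0.61 log units; beyond the scatter), which is only a floor: the limit of > 10000 nM in this assay, at which 1 of the 4 values shown sits.

Among these compounds, then, each of the three carboxy-bearing amino groups gives a higher number than hydroxy, and none of them goes against this, although the two steps with a full size are only modest.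

As far as these compounds go, what stays open is which part of the larger groups goes with the higher numbers, the carboxylic acid, the amine nitrogen or simply the extra heavy atoms. A plain piperidine without the carboxy group, a methoxy in place of the hydroxy, or a longer chain carrying the hydroxy would be the kind of comparison needed to separate these, and whether any of them would give a lower number than compound 4 cannot be told from the compounds shown.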